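Meta cyano analogue of a benzyl selenocyanate series

The compounds below may be only part of what the source reports. "The series", "measured", "known", "first", "only" and "open" are said of these compounds alone.

Measured so far:
compound 1, `N#C[Se]Cc1ccc([N+](=O)[O-])cc1`, 6860 nM
compound 2, `N#C[Se]Cc1cccc([N+](=O)[O-])c1`, 12200 nM
compound 3, `N#C[Se]Cc1ccc(C#N)cc1`, 13400 nM

Of the compounds shown here, three have been tested in an ADME assay on Jurkat cells (Homo sapiens) for cytotoxicity, read by trypan blue exclusion, with a stated time of 24 h; a higher number here means a weaker inhibitor, a lower number a stronger inhibitor. Compound 1, `N#C[Se]Cc1ccc([N+](=O)[O-])cc1`, gives 6860 nM in this assay. Compound 2, `N#C[Se]Cc1cccc([N+](=O)[O-])c1`, gives 12200 nM, and compound 3, `N#C[Se]Cc1ccc(C#N)cc1`, gives 13400 nM. Compounds 1 and 2 share the same atoms joined differently; the difference between the two cores is not broken down here.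

One structural change appears twice among these compounds. From compound 1 to compound 3 it is cyano in place of nitro on an aromatic carbon, a change placed para to a group of 4 heavy atoms, and it moved the number by a 2.0-fold higher number from compound 1 to compound 3 (0.29 log units; within the scatter). The same kind of change leads from compound 2 to the unmeasured compound 4, `N#C[Se]Cc1cccc(C#N)c1`: cyano in place of nitro on an aromatic carbon, here placed meta to a group of 4 heavy atoms.

For compound 4 in this assay, the step expected from compound 2 is a 1.6-fold higher number from compound 2 to compound 4 (0.21 log units; within the scatter), set beside the earlier 2.0-fold higher number from compound 1 to compound 3 (0.29 log units; within the scatter); this rests on the assumption that the same kind of change acts alike at the two places, which only compounds 1 and 3 support here. Compound 4 is therefore estimated at 20000 nM, with a range from 9000 nM to 45000 nM.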

Compound 4, half-maximal inhibitory concentration: 8710 nM
Compound 4: the middle estimate sits 2.3-fold (0.36 log units) above what was measured; measured number outside the range, below it.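

In this assay, cyano in place of nitro on an aromatic carbon gave a 1.4-fold lower number from compound 2 to compound 4 (0.15 log units; within the scatter) on the core of compound 2, and taken alone this step lies within the scatter. Set beside the earlier step on the core of compound 1, however, it does not repeat that result, and the two steps disagree: the same change on two cores in this assay, a 2.0-fold higher number (0.29 log units; within the scatter) from compound 1 to compound 3 and a 1.4-fold lower number (0.15 log units; within the scatter) from compound 2 to compound 4, 2.7-fold (0.44 log units) apart, beyond the scatter of two such steps. Among these compounds, this shows that, in this series, the change cannot safely be carried from one core to the other as a fixed step, but it does not show why the two cores part, nor which of the two steps is the more typical, and with only two pairs no rule can be drawn for any further core.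

The compounds shown leave open how the other groups that could stand on this aromatic carbon, such as an amine, a carboxylic acid or trifluoromethyl, would behave on these two cores. They also leave open whether the disagreement between the steps would persist if the selenocyanate were replaced by a thiocyanate or carried on a longer chain.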